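The compounds below may be only part of what the source reports. "The series", "measured", "known", "first", "only" and "open" are said of these compounds alone.

Measured compounds:
- Compound 1, `CCc1cccc(NC(=O)CN2CCN(c3ccccn3)CC2)c1`: 133 nM in an assay on cells for agonist activity at D(4) dopamine receptor (Homo sapiens), read by luminescence and beta-arrestin recruitment, with a stated time of 90 min; a higher number here means that more compound is needed for the effect, a lower number that less compound is needed
- Compound 2, `Cc1cccc(NC(=O)CN2CCN(c3ccc(Cl)cn3)CC2)c1`: "not active" (no number reported) in this assay
- Compound 3, `O=C(CN1CCN(c2ccccn2)CC1)Nc1cncnc1`: "not active" (no number reported) in this assay

Compound 3 stands without a number in this assay: the result for compound 3 is "not active" (no number reported), and compound 2 is the other entry without a number. Only compound 1 gives a concentration, 133 nM, so the series as a whole offers one measured anchor.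

The change from compound 3 to compound 4, `Cc1cccc(NC(=O)CN2CCN(c3ccccn3)CC2)c1`, is 3-methylphenyl in place of pyrimidin-5-yl on an amide-type nitrogen. Compound 4 carries the same remaining structure as compound 1, except that the aryl group on the amide nitrogen bears a 3-methylphenyl rather than the ethyl-substituted ring of compound 1. Compound 2 also carries a 3-methylphenyl but differs elsewhere, so it does not speak directly to this step.

Within the data shown here, no step between measured compounds exists for this change, so the size of the step in this assay cannot be read from the data. The expectation is that compound 4 moves from the inactive result of compound 3 towards a measurable concentration near that of compound 1, because compound 1 gives 133 nM with a closely related aryl group. For compound 4 the estimated value in this assay is 170 nM, with a range from 50 nM to 600 nM.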

Compound 4, half-maximal effective concentration: 394 nM
Estimate against measurement, compound 4: 2.3-fold (0.37 log units) below; the measured number falls inside the stated range.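

In this assay compound 4 gives 394 nM with 3-methylphenyl on the amide nitrogen, so a measurable response is retained with this group, whereas compound 3 with pyrimidin-5-yl at that place is reported as "not active", as is compound 2, which differs from compound 4 by a chlorine elsewhere in the molecule; neither comparison can be read as a step size, since those two entries have no number. Among these compounds, the one readable step shows that the small substituent on the phenyl ring still counts: going from ethyl to methyl gives a 3.0-fold higher number from compound 1 to compound 4 (0.47 log units; beyond the scatter) and so this pair separates two groups that differ by a single carbon. Nothing available here accounts for either the loss of a number with pyrimidin-5-yl or the change from ethyl to methyl.

The compounds shown leave open how a propyl chain or a plain phenyl ring with no substituent would read at this place, and so whether the trend from methyl to ethyl continues. They also leave open whether an amine or a carboxylic acid on that ring would keep a measurable response.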